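Removing the allylic hydroxy in the neolignan series

The compounds below may be only part of what the source reports. "The series", "measured", "known", "first", "only" and "open" are said of these compounds alone.

Three compounds of the series have numbers in an ADME assay on P3HR-1 cells (Homo sapiens) for cytotoxicity, read by microscopy and trypan blue exclusion, with a stated time of 2 days; on this read-out lower numbers stand for higher toxicity in this test and higher numbers for lower toxicity in this test. Compound 1 `COc1cc([C@H]2O[C@@H](c3cc(OC)c(OC)c(OC)c3)[C@H](C)[C@@H]2C)cc(OC)c1O` gives 65800 nM. Compound 2 `C=CCc1cc(OC)c(O[C@H](COC(C)=O)[C@H](O)c2cc(OC)c(OC)c(OC)c2)c(OC)c1` gives 195000 nM. Compound 3 `COc1cc([C@@H](OC(C)=O)[C@@H](C)Oc2c(OC)cc(/C=C/CO)cc2OC)cc(OC)c1OC` reaches only a limit of the assay, > 200000 nM, so no number is known for it; this is the limit of > 200000 nM in this assay, at which 1 of the 3 values shown sits. Compound 3 therefore stands at the weak end of what is shown, with compound 2 close to that limit and compound 1 the only member with a clearly smaller number.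

Compound 4 `C/C=C/c1cc(OC)c(O[C@H](C)[C@H](OC(C)=O)c2cc(OC)c(OC)c(OC)c2)c(OC)c1` has not yet been measured. Relative to compound 3 the change is hydrogen in place of hydroxy on a saturated chain carbon bound to a double-bonded chain carbon, that is, the hydroxymethyl becomes methyl and the 3-hydroxyprop-1-en-1-yl becomes prop-1-en-1-yl; the acetate and the three methoxy groups on each ring are kept. Among the compounds with values here, no measured pair differs in one place, so no computed step can be quoted. Given that compound 3 sits at a limit and compound 2 lies near it, the step from compound 3 to compound 4 is expected to be small, an at least 1.3-fold lower number from compound 3 to compound 4 (0.12 log units; that floor lies within the scatter), not clearly beyond the scatter in either direction. Compound 4 is estimated at 150000 nM, in the range 60000 nM to 250000 nM, with a real chance that only a limit is reported again.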

Compound 4, half-maximal cytotoxic concentration: 76800 nM
The estimate for compound 4 lay 2.0-fold (0.29 log units) above the measured number; the measured number falls inside the stated range.
By their numbers in this assay, from the lowest: compounds 1 and 4 (each within the scatter of the next); then compound 2. At a limit, above all of these: compound 3.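

In this assay, within the data shown here, hydrogen in place of hydroxy on a saturated chain carbon bound to a double-bonded chain carbon gives an at least 2.6-fold lower number from compound 3 to compound 4 (0.41 log units; beyond the scatter), the only step that can be read for a change in one place. This position is therefore not silent in this test: with prop-1-en-1-yl in place of 3-hydroxyprop-1-en-1-yl, compound 4 gives 76800 nM, a real number on the side of higher toxicity in this test. The step is a floor and not a size, because compound 3 is held at a limit of the assay: the limit of > 200000 nM in this assay, at which 1 of the 4 values shown sits.

The compounds shown leave open whether the shift follows from losing the hydroxy itself or would also appear with a methoxy, an amine or a carboxylic acid on that chain carbon, and whether a longer chain in place of prop-1-en-1-yl would move the number further. On these data alone, the true size of the step also stays open, and so does whether the same change reads the same way on a different core.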